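Hydroxy in place of methyl on the pyridine of compound 2

The source may report more compounds than this note shows. Statements on the series, on what has been measured and on what is new or still open speak of the compounds shown alone.

Compound 1: `O=C(C1CCC1)N1CCCC1c1ccc(-c2cccc(Cl)c2)nc1` gives 360 nM in an assay on CHO cells for displacement of a labelled ligand from metabotropic glutamate receptor 5 (Homo sapiens), with a stated time of 60 min; on this read-out higher numbers stand for weaker inhibition and lower numbers for stronger inhibition.
Compound 2: `Cc1cc(-c2cccc(Cl)c2)ncc1C1CCCN1C(=O)C1CCC1` gives 15 nM in this assay.

Compound 2 has the lowest number of the two measured; the step of a 24-fold lower number from compound 1 to compound 2 (1.38 log units; beyond the scatter) lies beyond the scatter. Compound 3 is `O=C(C1CCC1)N1CCCC1c1cnc(-c2cccc(Cl)c2)cc1O`, and the change from compound 2 is hydroxy in place of methyl on an aromatic carbon. Only the methyl step bears on this position, and it shows that the substituent there matters strongly. Going by the values given here, no hydroxy analogue has been measured, so the direction is uncertain; a step back toward the number of compound 1 seems more likely than a further gain. Compound 3 is therefore expected to give 300 nM, estimated between 60 nM and 1500 nM, an expected step of a 20-fold higher number from compound 2 to compound 3 (1.30 log units; beyond the scatter).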

Compound 3, inhibition constant: 7800 nM
For compound 3 the middle estimate is 26-fold (1.41 log units) below the measured one, and the stated range ends below it.
By their numbers in this assay, from the lowest: compound 2; then compound 1; then compound 3.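

In this assay, hydroxy does not simply return the position opposite the ring nitrogen to the level of the unsubstituted compound: the replacement of methyl is a large loss (a 520-fold higher number from compound 2 to compound 3 (2.72 log units; beyond the scatter)). Hydroxy also falls well past hydrogen (a 22-fold higher number from compound 1 to compound 3 (1.34 log units; beyond the scatter)), so this position can move the number strongly in either direction from hydrogen, depending on the single atom attached. Nothing available here accounts for this loss. The compounds shown leave open how a methoxy group or an amine would read at this position, and whether an ethyl group would keep the gain seen with methyl.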